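Swapping a Bromoalkyl Tail for a Methylsulfonyl Tail

The source may hold more compounds than are shown below. What is called first, only, known or untested is meant among the compounds shown, and "the series" means these compounds.

Two compounds share a core and differ only in the chain hanging from an oxygen on a saturated carbon. Compound 1, `COCCOCn1cc[n+](C)c1/C=N/O`, gives -2.81 in a physicochemical assay for lipophilicity; on this read-out higher numbers stand for higher lipophilicity and lower numbers for lower lipophilicity. Among the compounds with values here, compound 2, `C[n+]1ccn(COCC(C)(C)CBr)c1/C=N/O`, gives -0.81 in this assay, the higher of the two numbers measured; the one measured step is a number 2.00 log units higher from compound 1 to compound 2 (beyond the scatter). Compound 3, `C[n+]1ccn(COCCS(C)(=O)=O)c1/C=N/O`, is not yet measured. It differs from compound 2 by a group of 5 heavy atoms (2 carbon, 2 oxygen, 1 sulfur; no ring) in place of a group of 5 heavy atoms (4 carbon, 1 bromine; no ring), on a saturated chain carbon bound to an oxygen on a saturated carbon. Within the data shown here, only that single measured step bears on this change, and it ran the opposite way: it went with trading a chain built of carbon and oxygen for one built of carbon and bromine, whereas the change to compound 3 removes that carbon-and-bromine chain and brings in one built of carbon, oxygen and sulfur. A large downward step is therefore expected, of about a number 2.79 log units lower from compound 2 to compound 3 (beyond the scatter). Compound 3 is accordingly estimated at -3.6, with a range from -4.4 to -2.8.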

Compound 3, distribution coefficient: < -3.3
Compound 3 was reported as a limit; the forecaster's own chance of this, stated with the estimate: 5%; the middle value lies beyond the limit too.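

In this assay, compound 3 is reported only as a limit, < -3.3. Even so, the earlier compounds had shown only an upward move at this place on a saturated chain carbon bound to an oxygen on a saturated carbon, and the exchange of the bromine-bearing chain for (methylsulfonyl)methyl now shows a large move the other way: a number at least 2.49 log units lower from compound 2 to compound 3 (beyond the scatter). The exchange of methoxy for methylsulfonyl adds a second new fact, with a number at least 0.49 log units lower from compound 1 to compound 3 (beyond the scatter), so compound 3 sits under both earlier compounds.

How far down compound 3 really lies stays open: the limit of < -3.3 in this assay, at which 1 of the 3 values shown sits. The compounds shown also leave open where a chain ending in an amine or a carboxylic acid, or a longer chain carrying the methylsulfonyl group, would fall on this scale.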